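This account rests on a few compounds, and the source may have more. Where it says the series, first, only, none or still open, it means among the compounds named here.

Compound 1 `COc1ccc(OC)c(/C=N/NC(=O)Nc2ccc(Oc3ccnc(-c4nncn4CCN(C)C)c3)c(F)c2)c1`: "not determined" (no result reported).
Compound 2 `CN(C)CCn1cnnc1-c1cc(Oc2ccc(NC(=O)N/N=C/c3c[nH]c4ccccc34)cc2F)ccn1`: 3620 nM.
Compound 3 `COc1ccc(/C=N/NC(=O)Nc2ccc(Oc3ccnc(-c4nncn4CCN(C)C)c3)c(F)c2)c(OC)c1OC`: "not determined" (no result reported).

Compound 1 stands without a number in an ADME assay on WI-38 cells (Homo sapiens) for cytotoxicity, read by MTT assay, with a stated time of 72 h (a higher number here means a weaker inhibitor, a lower number a stronger inhibitor), and the same is true of compound 3. The only number among these compounds belongs to compound 2, which gives 3620 nM in this assay. Compound 4 `CN(C)CCn1cnnc1-c1cc(Oc2ccc(NC(=O)N/N=C/c3c(Cl)cccc3Cl)cc2F)ccn1` differs from compound 1 by 2,6-dichlorophenyl in place of 2,5-dimethoxyphenyl on a carbon with a double bond to nitrogen. For the measured compounds named here, no step between measured compounds is available, so the size of the change from compound 1 to compound 4 in this assay cannot be read from the data. With compound 2 as the only anchor, no shift beyond the usual scatter is expected in either direction. Compound 4 is therefore expected to give about 4000 nM in this assay, within a range of 1200 nM to 15000 nM.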

Compound 4, half-maximal inhibitory concentration: 3320 nM
Estimate against measurement, compound 4: 1.2-fold (0.08 log units) above; the range from low to high includes it.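

In this assay, for the compounds shown here, 2,6-dichlorophenyl in place of 1H-indol-3-yl on a carbon with a double bond to nitrogen gives a 1.1-fold lower number from compound 2 to compound 4 (0.04 log units; within the scatter), the first step that can be read at this place. A fused ring with a nitrogen hydrogen and a chlorinated phenyl thus leave the value within the scatter. Nothing measured here accounts for this.

Steps involving compound 1 or compound 3 cannot be read, as neither has a number. From the compounds shown here alone, whether a carboxylic acid or an aliphatic amine at this place would shift the value remains open.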